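The compounds below may be only part of what the source reports. "The series", "measured", "known", "first", "only" and "open" are said of these compounds alone.

Values in a functional assay on cells (Homo sapiens) for antiproliferative activity, read by MTT assay, with a stated time of 48 h; a lower number here means a stronger inhibitor, a higher number a weaker inhibitor:
- Compound 1 `CN(C)CCn1c(N)c(-c2nc3ccccc3[nH]2)c2nc(C#N)c(C#N)nc21`: 43500 nM
- Compound 2 `CCCn1c(N)c(-c2nc3ccccc3[nH]2)c2nc(C#N)c(C#N)nc21`: > 50000 nM, a limit of the assay and not a number
- Compound 3 `CN(C)CCCn1c(N)c(-c2nc3ccccc3[nH]2)c2nc(C#N)c(C#N)nc21`: 1820 nM

Compound 3 stands lowest of the three, with a 24-fold lower number from compound 1 to compound 3 (1.38 log units; beyond the scatter) and an at least 27-fold lower number from compound 2 to compound 3 (1.43 log units; beyond the scatter). Both steps alter only the chain on the aromatic nitrogen.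

Compound 4 `CN(C)CCCn1c(N)c(-c2nc3ccccc3o2)c2nc(C#N)c(C#N)nc21` keeps the 3-(dimethylamino)propyl group and carries 1,3-benzoxazol-2-yl in place of 1H-benzimidazol-2-yl on an aromatic carbon. For the measured compounds named here, no measured step changes this group, so those large steps give no direct guide to its size or direction. Taking compound 3 at 1820 nM as the base, only a modest rise is expected, with wide uncertainty.

The expected step is a 1.6-fold higher number from compound 3 to compound 4 (0.22 log units; within the scatter).

The estimate for compound 4 is 3000 nM, expected to fall from 600 nM to 15000 nM.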

Compound 4, half-maximal inhibitory concentration: 5640 nM
For compound 4 the middle estimate is 1.9-fold (0.27 log units) below the measured one, and the stated range covers the measured number.
By their numbers in this assay, from the lowest: compound 3; then compound 4; then compound 1. At a limit, above all of these: compound 2.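

In this assay, for the compounds shown here, 1,3-benzoxazol-2-yl in place of 1H-benzimidazol-2-yl on the aromatic carbon gives a 3.1-fold higher number from compound 3 to compound 4 (0.49 log units; beyond the scatter), the first step read at this position; the earlier steps altered only the chain on the aromatic nitrogen. The entering group carries 0 hydrogen-bond donors where the leaving group carries 1, but no measured property shown here accounts for the step.

Open, as far as these compounds go, is whether the ring oxygen or the missing ring hydrogen drives this step. A 1-methyl-1H-benzimidazol-2-yl or a 1,3-benzothiazol-2-yl group at this position would separate the two.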